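The source may hold more compounds than are shown below. What is called first, only, known or untested is meant among the compounds shown, and "the series" means these compounds.

Compound 1 `COc1cccc(S(=O)(=O)/C=C/c2ccccn2)c1`: 74%
Compound 2 `COc1cccc(S(=O)(=O)/C=C/c2ncccc2Cl)c1`: 22%
Compound 3 `COc1ccccc1S(=O)(=O)/C=C/c1cccnc1Cl`: 77%

The three measured compounds were tested in an ADME assay on microsomes from liver (Homo sapiens) for metabolic stability, read by LC-MS, using NADPH, with stated times of 5 min and 30 min, tested at 1 uM; on this read-out lower numbers stand for a less stable compound and higher numbers for a more stable compound. The change chloro in place of hydrogen on an aromatic carbon produced a number 52 percentage points lower from compound 1 to compound 2 (beyond the scatter), a large drop. Compound 3 is built on a different core from compound 1; the difference between the two cores is not broken down here. The values of compound 1 and compound 3 lie within the scatter of each other, so no order is read between them, while compound 3 stands well apart from compound 2.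

Compound 4 `COc1ccccc1S(=O)(=O)/C=C/c1ccc(Cl)nc1Cl` has not yet been measured. It differs from compound 3 by chloro in place of hydrogen on an aromatic carbon. Among the measured compounds shown here, this is the same kind of change as the one from compound 1 to compound 2, but not the same: in the earlier case the chloro entered ortho to a large group, two atoms from the ring nitrogen, whereas here it enters next to the ring nitrogen, meta to a chloro group and para to a large group. Because the earlier step gave a number 52 percentage points lower from compound 1 to compound 2 (beyond the scatter), a downward step is expected for compound 4 as well; the different surroundings of the new chloro leave its size uncertain. Compound 4 is estimated at 38%, between 15% and 62%, meaning an expected a number 39 percentage points lower from compound 3 to compound 4 (beyond the scatter).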

Compound 4, percent of the compound remaining: 18%
Estimate against measurement, compound 4: 20 percentage points above, within the range that was stated.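

In this assay, chloro in place of hydrogen on an aromatic carbon again gave a large fall, a number 59 percentage points lower from compound 3 to compound 4 (beyond the scatter). Set beside the earlier step, the change carried across the two cores with a closely matching size, and no difference between the two steps can be read: the same change on two cores in this assay, a number 52 percentage points lower (beyond the scatter) from compound 1 to compound 2 and a number 59 percentage points lower (beyond the scatter) from compound 3 to compound 4, 7 percentage points apart, within the scatter of two such steps This agreement rests on only two pairs of compounds, and the chloro enters at a different place in each pair, so it establishes no general rule for other cores and does not explain why the number falls.

The compounds shown leave open whether a fluoro group, an amine or a carboxylic acid in place of the chloro would bring a fall of similar size. They also leave open how the stability would respond if the methoxy group were replaced by a longer chain, with or without the chloro present.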